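The source may hold more compounds than are shown below. What is called first, only, known or untested is meant among the compounds shown, and "the series" means these compounds.

Three analogues share the core of compound 1 `CC(NC(=O)c1ccc(C(=N)N)cc1)C(C)(C)C(=O)N1CCC(CC(=O)O)CC1` and have been run in an in vivo ADME assay on the whole organism (Cavia porcellus) (on this read-out lower numbers stand for a shorter-lived compound and higher numbers for a longer-lived compound), where compound 1 gives 0.883 h. Compound 2 `C/C=C/C(NC(=O)c1ccc(C(=N)N)cc1)C(C)(C)C(=O)N1CCC(CC(=O)O)CC1` gives 0.933 h in this assay, and compound 3 `CCCCC(NC(=O)c1ccc(C(=N)N)cc1)C(C)(C)C(=O)N1CCC(CC(=O)O)CC1` gives 1.03 h. Compound 2 stands second highest of the three, set apart from compound 1 by a 1.1-fold higher number from compound 1 to compound 2 (0.02 log units; within the scatter) and from compound 3 by a 1.1-fold higher number from compound 2 to compound 3 (0.04 log units; within the scatter); the remaining step, a 1.2-fold higher number from compound 1 to compound 3 (0.07 log units; within the scatter), is likewise within the scatter. Compound 4 `CC(C)(C(=O)N1CCC(CC(=O)O)CC1)C(NC(=O)c1ccc(C(=N)N)cc1)c1ccc(Cl)cc1` is not yet measured and differs from compound 2 by 4-chlorophenyl in place of prop-1-en-1-yl on a saturated chain carbon bound to an amide-type nitrogen and a saturated chain carbon. The two earlier changes at this same place, a 1.1-fold higher number from compound 1 to compound 2 (0.02 log units; within the scatter) and a 1.1-fold higher number from compound 2 to compound 3 (0.04 log units; within the scatter), both stayed within the scatter, so for compound 4 an estimated step of no more than the scatter is expected in this assay, namely a 1.0-fold higher number from compound 2 to compound 4 (0.01 log units; within the scatter). Compound 4 is therefore expected to give 0.95 h, with a range of 0.6 h to 1.5 h.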

Compound 4, half-life: 1.2 h
For compound 4 the middle estimate is 1.3-fold (0.10 log units) below the measured one; the range from low to high includes it.
By their numbers in this assay, from the lowest: compounds 1, 2, 3 and 4 (each within the scatter of the next).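

At this place, on a saturated chain carbon bound to an amide-type nitrogen and a saturated chain carbon, 4-chlorophenyl brings the first aromatic ring into the set, yet in this assay every step to it stays within the scatter (a 1.3-fold higher number from compound 2 to compound 4 (0.11 log units; within the scatter)), (a 1.2-fold higher number from compound 3 to compound 4 (0.07 log units; within the scatter)) and (a 1.4-fold higher number from compound 1 to compound 4 (0.13 log units; within the scatter)). Among the compounds shown, half-life therefore does not separate the open chains from this aromatic ring. No supporting data bear on these values. From the compounds shown here alone, whether an amine or a hydroxyl group at this place would give a step beyond the scatter remains open.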